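This account rests on a few compounds, and the source may have more. Where it says the series, first, only, none or still open, it means among the compounds named here.

Measured so far:
compound 1, `COC(=O)C#CC(O/C=C/C(=O)OC)C(C)c1ccccc1`: 1200 nM
compound 2, `CC(C)C(C#CC(=O)OC(C)(C)C)O/C=C/C(=O)OC(C)(C)C`: 4800 nM

In a functional assay on SW1573 cells (Homo sapiens) for antiproliferative activity, read by sulforhodamine B assay, with a stated time of 48 h (on this read-out lower numbers stand for stronger inhibition of growth and higher numbers for weaker inhibition of growth), compound 1 gives the lowest number of the two; compound 2 gives a higher number, a gap beyond the scatter. Among the compounds with values here, no single-change pair has been measured, so the size of a step at this position is not known from data.

Compound 3, `COC(=O)C#CC(O/C=C/C(=O)OC)C(C)C`, differs from compound 1 by methyl in place of phenyl on a saturated chain carbon bound to two saturated chain carbons. Compound 2, also carrying a small branched alkyl in place of phenyl, shows the weaker number, so compound 3 is expected to weaken as well: the estimated step from compound 1 to compound 3 is a 2.5-fold higher number from compound 1 to compound 3 (0.40 log units; beyond the scatter). Compound 3 is therefore estimated at 3000 nM, within a range of 1200 nM to 8000 nM.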

Compound 3, concentration for 50% growth inhibition: 750 nM
Compound 3: the middle estimate sits 4.0-fold (0.60 log units) above what was measured; measured number outside the range, below it.
By their numbers in this assay, from the lowest: compounds 3 and 1 (each within the scatter of the next); then compound 2.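

In this assay, methyl in place of phenyl on a saturated chain carbon bound to two saturated chain carbons gives a 1.6-fold lower number from compound 1 to compound 3 (0.20 log units; within the scatter). The six-membered aromatic ring at this position can therefore be lost without a shift beyond the scatter, so this single change leaves the read-out effectively unmoved. Nothing available explains why the two compounds read alike. Still open, on these data alone, is whether a longer chain, an amine or a carboxylic acid at this position would also leave the number unmoved. Whether a group with hydrogen-bond donors or acceptors is tolerated here is equally unresolved.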